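This account rests on a few compounds, and the source may have more. Where it says the series, first, only, none or still open, it means among the compounds named here.

Measured so far in a functional assay on HT-29 cells (Homo sapiens) for inhibition, read by MTT assay, with a stated time of 2 days; a lower number here means a stronger inhibitor, a higher number a weaker inhibitor:
- compound 1 `Nc1cccc(/C=C/c2ccccc2)c1` gives 12.9 ug/mL
- compound 2 `Nc1cccc(/C=C/c2ccccc2O)c1` gives 30.4 ug/mL
- compound 3 `Nc1cccc(/C=C/c2cccc(O)c2)c1` gives 43 ug/mL

Among these three, compound 1 has the lowest number and is thus the strongest inhibitor here; the steps of a 2.4-fold higher number from compound 1 to compound 2 (0.37 log units; beyond the scatter) and a 3.3-fold higher number from compound 1 to compound 3 (0.52 log units; beyond the scatter) both lie beyond the scatter. Compound 4 `COc1ccc(/C=C/c2cccc(N)c2)cc1` has not yet been measured. It differs from compound 1 in one place: methoxy in place of hydrogen on an aromatic carbon. The two measured steps each put a hydroxy in place of hydrogen on an aromatic carbon, and each gave a modest weakening. Methoxy is a different group, so those steps bear on compound 4 only loosely, yet a modest weakening remains the expectation. In this assay compound 4 is therefore expected to show a step of a 1.7-fold higher number from compound 1 to compound 4 (0.23 log units; within the scatter), giving an estimate of 22 ug/mL (range 10 ug/mL to 50 ug/mL).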

Compound 4, half-maximal inhibitory concentration: 16.3 ug/mL
Beside the measured number, compound 4's estimate is 1.3-fold (0.13 log units) above it; low and high end bracket the measured number.
By their numbers in this assay, from the lowest: compounds 1, 4, 2 and 3 (each within the scatter of the next, the first and the last beyond it).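

In this assay, putting methoxy in place of hydrogen on this aromatic carbon, para to a group of 9 heavy atoms, gives a 1.3-fold higher number from compound 1 to compound 4 (0.10 log units; within the scatter) and so leaves the two numbers indistinguishable. The earlier hydroxy steps both lay beyond the scatter, so this ring can carry at least one added group without a measurable cost. From the compounds shown here alone, whether hydroxy at this same position would match methoxy stays open, as does the outcome with ethoxy or a carboxylic acid there. Nothing available gives a reason for the contrast between the methoxy and hydroxy steps.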